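The source may report more compounds than this note shows. Statements on the series, on what has been measured and on what is new or still open speak of the compounds shown alone.

The measured compounds:

Compound 1, `COc1ccc([C@H]2CC(=O)N(Cc3cccc(N)c3)C2)cc1OC1CCCC1`: in a functional assay on HEK293 cells (Homo sapiens) for cytotoxicity (on this read-out higher numbers stand for lower toxicity in this test and lower numbers for higher toxicity in this test), compound 1 reaches only the assay limit of > 10000 nM.

Compound 2, `COc1ccc([C@H]2CC(=O)N(Cc3cccc([N+](=O)[O-])c3)C2)cc1OC1CCCC1`: in this assay compound 2 likewise reaches only the assay limit of > 10000 nM.

Compound 3, `COc1ccc([C@H]2CC(=O)N(c3ccccc3)C2)cc1OC1CCCC1`: in this assay compound 3 again stands at the assay limit of > 10000 nM.

Compound 3 therefore stands where every measured compound stands, namely at the limit of > 10000 nM in this assay, at which 3 of the 3 values shown sit. Going by the values given here, none of the measured values is a number; each is a limit, and so no compound can be placed higher or lower than another in this assay.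

Compound 4, `COc1ccc([C@H]2CC(=O)N(c3ccccc3N)C2)cc1OC1CCCC1`, differs from compound 3 by amino in place of hydrogen on an aromatic carbon. The steps that come nearest to it are a step that the two limits leave unreadable from compound 1 to compound 3 and a step that the two limits leave unreadable from compound 2 to compound 3, both of which exchange the whole group on the ring nitrogen, and a step that the two limits leave unreadable from compound 1 to compound 2, which exchanges nitro for amino on the pendant ring. All three are steps between two limits and their size cannot be read. Among the compounds with values here, no measured step carries an amino group onto the phenyl that sits on the ring nitrogen.

With every value at the limit, no step beyond the scatter is expected in this assay, in either direction. Compound 4 is expected to give about 15000 nM, within a range from 5000 nM to 50000 nM, most likely reported again as a limit. The estimated step is a step that the limit leaves unreadable from compound 3 to compound 4.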

Compound 4, half-maximal cytotoxic concentration: > 10000 nM
Compound 4 was reported as a limit; the forecaster's own chance of this, stated with the estimate: 85%; the middle value lies beyond the limit too.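

In this assay compound 4 gives > 10000 nM, which is a limit of the assay. The steps to compound 4 from compound 1, compound 2 and compound 3 cannot be read, and the values shown stand together at: the limit of > 10000 nM in this assay, at which 4 of the 4 values shown sit.

The compounds shown leave open whether any change on the shared core would give a number in this assay rather than a limit.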